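The compounds below may be only part of what the source reports. "The series", "measured", "known", "first", "only" and "open" are said of these compounds alone.

In an assay on CHO cells for displacement of a labelled ligand from adenosine receptor A3 (Homo sapiens), read by scintillation counting, with a stated time of 120 min, tested at 10 uM (on this read-out higher numbers stand for more inhibition at the one concentration tested (going by the name of the read-out) and lower numbers for less inhibition), compound 1 `Nc1scc(CN2CCN(c3cccc(C(F)(F)F)c3)CC2)c1C(=O)c1ccc(Cl)cc1` gives 0%. Compound 2 `Nc1scc(CN2CCN(c3ccc(Cl)c(C(F)(F)F)c3)CC2)c1C(=O)c1ccc(Cl)cc1` differs from compound 1 by chloro in place of hydrogen on an aromatic carbon, and in this assay compound 2 gives 3%. Compound 3 `Nc1scc(CN2CCN(c3ccccc3Cl)CC2)c1C(=O)c1ccc(Cl)cc1` differs from compound 1 in its core by 2-chlorophenyl in place of 3-(trifluoromethyl)phenyl on an amine nitrogen in a ring; in this assay compound 3 gives 0%, which is no change at the digits printed from compound 1 to compound 3 (within the scatter) and a number 3 percentage points lower from compound 2 to compound 3 (within the scatter). Compound 4 `Nc1scc(CN2CCN(c3c(Cl)cccc3Cl)CC2)c1C(=O)c1ccc(Cl)cc1` has not been measured; it differs from compound 3 by chloro in place of hydrogen on an aromatic carbon. This is the same kind of change as that from compound 1 to compound 2, but the surroundings differ: in compound 2 the chloro enters ortho to a trifluoromethyl group and para to a large group, in compound 4 ortho to a large group and meta to a chloro group. That earlier step was a number 3 percentage points higher from compound 1 to compound 2 (within the scatter). The step from compound 3 to compound 4 is expected to be a number 1 percentage points higher from compound 3 to compound 4 (within the scatter), resting on that earlier step. Compound 4 is expected to give 1% in this assay, within -5% to 8%.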

Compound 4, a percentage reported as inhibition, at one concentration (the size of the read-out at that concentration, not a potency): 1%
Compound 4: the middle estimate sits on the measured number at the digits printed, and the stated range covers the measured number.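

In this assay, adding the chloro gives a number 1 percentage points higher from compound 3 to compound 4 (within the scatter), while the wider comparisons with compound 4 give a number 2 percentage points lower from compound 2 to compound 4 (within the scatter) and a number 1 percentage points higher from compound 1 to compound 4 (within the scatter). Set beside each other, the two chloro steps do not differ beyond what repeated measurements would allow: the same change on two cores in this assay, a number 3 percentage points higher (within the scatter) from compound 1 to compound 2 and a number 1 percentage points higher (within the scatter) from compound 3 to compound 4, 2 percentage points apart, within the scatter of two such steps This shows only that the change left both cores with numbers that lie within the scatter of each other, and it does not show how the change would carry over to a compound with clear inhibition in this assay. Going by these compounds, whether a methoxy group or a nitrile in place of the chloro would give a number beyond the scatter stays open. So does the effect of any change away from the aryl group on the amine nitrogen.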